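The source may hold more compounds than are shown below. What is called first, only, known or untested is meant among the compounds shown, and "the series" means these compounds.

Measured compounds:
compound 1 `C=C1CC[C@@H]2[C@](C)(COC(C)=O)[C@H](OC(C)=O)CC[C@@]2(C)[C@@H]1C/C=C1/C(=O)OC[C@H]1OC(C)=O`, in a functional assay on ASK cells (Rattus norvegicus) for cytotoxicity, read by sulforhodamine B assay (on this read-out lower numbers stand for an effect already at smaller amounts and higher numbers for an effect only at larger amounts of compound), compound 1 gives 11.4 uM
compound 2 `C=C1CC[C@@H]2[C@](C)(CO[Si](C(C)C)(C(C)C)C(C)C)[C@H](OC(C)=O)CC[C@@]2(C)[C@@H]1C/C=C1/C(=O)OC[C@H]1OC(C)=O`, compound 2 gives 7.56 uM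
compound 3 `C=C1CC[C@@H]2[C@](C)(CO[Si](C(C)C)(C(C)C)C(C)C)[C@H](O)CC[C@@]2(C)[C@@H]1C/C=C1/C(=O)OC[C@H]1O`, compound 3 gives 2.85 uM

Compound 3 has the lowest number of the three. How the core of compound 3 differs from that of compound 2 is not broken down here. Compound 4 `C=C1CC[C@@H]2[C@](C)(COC(C)=O)[C@H](O)CC[C@@]2(C)[C@@H]1C/C=C1/C(=O)OC[C@H]1O` is not yet measured in this assay. It differs from compound 3 by a group of 3 heavy atoms (2 carbon, 1 oxygen; no ring) in place of a group of 10 heavy atoms (9 carbon, 1 silicon; no ring), on an oxygen on a saturated carbon. The same change has been made once before, from compound 2 to compound 1 (a group of 3 heavy atoms (2 carbon, 1 oxygen; no ring) in place of a group of 10 heavy atoms (9 carbon, 1 silicon; no ring), on an oxygen on a saturated carbon), where the step was a 1.5-fold higher number from compound 2 to compound 1 (0.18 log units; within the scatter). A step of like size is expected for compound 4, that is a 1.5-fold higher number from compound 3 to compound 4 (0.18 log units; within the scatter), resting on that single earlier pair. Compound 4 is therefore estimated at 4.3 uM, expected between 2 uM and 9 uM.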

Compound 4, concentration for half-maximal effect: 16.7 uM
For compound 4 the middle estimate is 3.9-fold (0.59 log units) below the measured one, and the stated range ends below it.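

In this assay, acetyl in place of the silicon-bearing group of 10 heavy atoms gives a 5.9-fold higher number from compound 3 to compound 4 (0.77 log units; beyond the scatter), and the size of this change does not carry over from one core to the other: the same change on two cores in this assay, a 1.5-fold higher number (0.18 log units; within the scatter) from compound 2 to compound 1 and a 5.9-fold higher number (0.77 log units; beyond the scatter) from compound 3 to compound 4, 3.9-fold (0.59 log units) apart, beyond the scatter of two such steps A step read on one of these cores is therefore a poor guide to the same step on the other. Two pairs do not show which difference between the cores sets the size of the step, nor what size it would take on a third core.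

The compounds shown leave open how a free hydroxyl, a longer acyl chain or a benzoyl group on that oxygen would read in this assay.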